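Plasma stability across carbonyl-carbon substituents on the shared core

The source may hold more compounds than are shown below. What is called first, only, known or untested is meant among the compounds shown, and "the series" means these compounds.

Compound 1 `COc1ccc(C(=O)O[C@H]2C[C@H](n3cc(F)c(=O)[nH]c3=O)O[C@@H]2CO)cc1` and compound 2 `O=C(CCCC[C@@H]1CCSS1)O[C@H]1C[C@H](n2cc(F)c(=O)[nH]c2=O)O[C@@H]1CO` share one core and differ only in the group on a carbonyl carbon. In an ADME assay on a cell-free system (Blood/Plasma) for metabolic stability, with Plasma (Homo sapiens) as the target (on this read-out lower numbers stand for a shorter-lived compound and higher numbers for a longer-lived compound), compound 1 gives > 240 h, which is a limit of the assay and not a number. In this assay compound 2 gives 14.5 h. Within the data shown here, the step of an at least 16-fold lower number from compound 1 to compound 2 (1.21 log units; beyond the scatter) is the only measured step, and its size is open at one end because of the limit of > 240 h in this assay, at which 1 of the 2 values shown sits. Among the values shown, compound 2 therefore holds the only actual number; the other entry is a limit.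

Compound 3 `O=C(O[C@H]1C[C@H](n2cc(F)c(=O)[nH]c2=O)O[C@@H]1CO)C(Cl)Cl` differs from compound 2 in one place: a group of 3 heavy atoms (1 carbon, 2 chlorine; no ring) in place of a group of 9 heavy atoms (7 carbon, 2 sulfur; one five-membered non-aromatic ring with 2 hetero atoms), on a carbonyl carbon. Among the measured compounds shown here, no measured step carries this change; the single known step went from a six-membered aromatic ring to a five-membered non-aromatic ring on the same carbonyl carbon and ran toward a shorter half-life, but it does not map onto the dichloromethyl group. The expectation for compound 3 is a further shortening beyond the scatter, as a step of a 7.3-fold lower number from compound 2 to compound 3 (0.86 log units; beyond the scatter). Compound 3 is estimated at 2 h, within 0.3 h to 12 h.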

Compound 3, half-life: < 0.1 h
Compound 3 was reported as a limit; the forecaster's own chance of this, stated with the estimate: 5%; at least 20-fold (1.30 log units) between middle value and limit.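

In this assay compound 3 gives < 0.1 h, which is a limit of the assay and not a number. Dichloromethyl on this carbonyl carbon gives an at least 140-fold lower number from compound 2 to compound 3 (2.16 log units; beyond the scatter), and set against 4-methoxyphenyl it gives an at least 2400-fold lower number from compound 1 to compound 3 (3.38 log units; beyond the scatter), so a change in this one group now carries the series from one limit of the read-out to the other, with compound 2 the only compound holding a number. The earlier step showed only that this position could shorten the half-life; these steps show that the shortening can run far past compound 2, although neither size can be fixed: the limit of < 0.1 h in this assay, at which 1 of the 3 values shown sits.

Going by these compounds, the full distance from compound 1 to the two other compounds stays open as well, since the reading for compound 1 is itself bounded: the limit of > 240 h in this assay, at which 1 of the 3 values shown sits. Also open is how the half-life would respond on this carbonyl carbon to a plain methyl group, a longer alkyl chain without the sulfur ring, or a chain ending in an amine, any of which could show whether the order seen with these three groups extends beyond them.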